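Notes on the step from compound 3 to compound 4

The source may hold more compounds than are shown below. What is called first, only, known or untested is meant among the compounds shown, and "the series" means these compounds.

- compound 1 `CN(C)CCCCCn1c2c(c3ccccc31)C(=O)c1c[n+]([O-])c3ccccc3c1C2=O`: 240 nM
- compound 2 `O=C1c2c[n+]([O-])c3ccccc3c2C(=O)c2c1c1ccccc1n2Cc1cn(CC(O)CO)nn1`: 1070 nM
- compound 3 `CN1CCN(CCCn2c3c(c4ccccc42)C(=O)c2c[n+]([O-])c4ccccc4c2C3=O)CC1`: 230 nM

In a toxicity assay on L02 cells (Homo sapiens) for cytotoxicity, read by MTT assay, with a stated time of 72 h (on this read-out lower numbers stand for stronger inhibition and higher numbers for weaker inhibition), compound 3 stands level with compound 1, while compound 2 gives the highest number, 1070 nM. Compound 4 `CN1CCN(CCCCCn2c3c(c4ccccc42)C(=O)c2c[n+]([O-])c4ccccc4c2C3=O)CC1` differs from compound 3 by 2-(4-methylpiperazin-1-yl)ethyl in place of 4-methylpiperazin-1-yl on a saturated chain carbon, three bonds along the chain from an aromatic nitrogen. The same difference reads 3-(4-methylpiperazin-1-yl)propyl to 5-(4-methylpiperazin-1-yl)pentyl. The most relevant measured step is a 1.0-fold lower number from compound 1 to compound 3 (0.02 log units; within the scatter). The larger steps, a 4.5-fold higher number from compound 1 to compound 2 (0.65 log units; beyond the scatter) and a 4.7-fold lower number from compound 2 to compound 3 (0.67 log units; beyond the scatter), both involve the triazolyl group of compound 2, which compound 4 lacks, so they bear less on this change. No step beyond the scatter is expected, and the estimated step is a 1.0-fold lower number from compound 3 to compound 4 (0.02 log units; within the scatter). For compound 4 the estimated value is 220 nM, with an expected range of 100 nM to 500 nM.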

Compound 4, half-maximal inhibitory concentration: 1640 nM
Beside the measured number, compound 4's estimate is 7.5-fold (0.87 log units) below it, and the stated range ends below it.
By their numbers in this assay, from the lowest: compounds 3 and 1 (each within the scatter of the next); then compounds 2 and 4 (each within the scatter of the next).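

In this assay, the move from 3-(4-methylpiperazin-1-yl)propyl to 5-(4-methylpiperazin-1-yl)pentyl is not neutral at this position (a 7.1-fold higher number from compound 3 to compound 4 (0.85 log units; beyond the scatter)). With the pentyl chain, 4-methylpiperazin-1-yl and dimethylamino are also not interchangeable (a 6.8-fold higher number from compound 1 to compound 4 (0.83 log units; beyond the scatter)), and compound 4 stands level with the triazolyl compound (a 1.5-fold higher number from compound 2 to compound 4 (0.19 log units; within the scatter)). No measured evidence on the cause of these steps is available. Open, from the compounds shown here alone, is how a butyl or hexyl chain carrying 4-methylpiperazin-1-yl would read, and whether morpholin-4-yl at the chain end would follow the same step.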